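A few compounds are considered here, and "the series" means these few. Any claim that something is new, unique, unknown or untested is made for them only; others in the source may bear on it.

In a functional assay on LoVo cells (Homo sapiens) for inhibition, read by MTT assay, with a stated time of 24 h (a lower number here means a stronger inhibitor, a higher number a weaker inhibitor), compound 1 `CC1(C)[C@H]2CC[C@]1(C)N(Cc1cn(-c3ccc(Br)cc3)nn1)C(=O)C2` gives 60 nM and compound 2 `Cc1ccc(-n2cc(CN3C(=O)C[C@@H]4CC[C@@]3(C)C4(C)C)nn2)cc1` gives 50 nM while compound 3 `CC1(C)[C@H]2CC[C@]1(C)N(Cc1cn(-c3ccc(Cl)cc3)nn1)C(=O)C2` gives 160 nM as the highest of the three numbers. Compound 4 `COc1ccc(-n2cc(CN3C(=O)C[C@@H]4CC[C@@]3(C)C4(C)C)nn2)cc1` awaits measurement. It carries methoxy in place of chloro on an aromatic carbon at the place where the three measured compounds differ. Two measured steps into the chloro compound bear on it: a 2.7-fold higher number from compound 1 to compound 3 (0.43 log units; beyond the scatter) and a 3.2-fold higher number from compound 2 to compound 3 (0.51 log units; beyond the scatter) are both modest, whereas a 1.2-fold lower number from compound 1 to compound 2 (0.08 log units; within the scatter) stays small. For the measured compounds named here, no methoxy compound has been measured, so a modest move to a lower number in this assay is only a tentative expectation. The expected size is a 2.0-fold lower number from compound 3 to compound 4 (0.30 log units; within the scatter) at this stage. For compound 4 the estimated value is 80 nM with an expected range from 30 nM to 220 nM in this assay when measured.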

Compound 4, half-maximal inhibitory concentration: 70 nM
Beside the measured number, compound 4's estimate is 1.1-fold (0.06 log units) above it; the range from low to high includes it.
By their numbers in this assay, from the lowest: compounds 2, 1 and 4 (each within the scatter of the next); then compound 3.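

In this assay the change from 4-chlorophenyl to 4-methoxyphenyl gives a 2.3-fold lower number from compound 3 to compound 4 (0.36 log units; beyond the scatter) and so a step beyond the scatter in the direction of the bromo and methyl compounds. With a 1.4-fold higher number from compound 2 to compound 4 (0.15 log units; within the scatter) and a 1.2-fold higher number from compound 1 to compound 4 (0.07 log units; within the scatter) both within the scatter, methoxy joins methyl and bromo at this place, leaving chloro alone apart among the four compounds. Nothing measured here gives a reason for chloro standing apart. On these data alone, it remains open whether an amine or a carboxylic acid at this place would stay with that group, and whether a longer chain such as ethoxy would.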